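The source may hold more compounds than are shown below. What is called first, only, known or untested is meant among the compounds shown, and "the series" means these compounds.

Measured compounds in an assay for inhibition of serine/threonine-protein kinase PAK 4 (Homo sapiens), read by FRET and Z'-LYTE, with a stated time of 60 min, tested at 0.5 uM, in the presence of a further agent that is not named here; a lower number here means a weaker effect, a higher number a stronger effect of the compound at the concentration tested: compound 1 `CC(OC(=O)N1CCN(C(=O)c2nc(Nc3cc(C4CC4)[nH]n3)c3cc(Cl)ccc3n2)C[C@H]1C)OC(=O)C(C)(C)C` gives -6.9%; compound 2 `CC(OC(=O)C(C)C)OC(=O)N1CCN(C(=O)c2nc(Nc3cc(C4CC4)[nH]n3)c3cc(Cl)ccc3n2)C[C@H]1C` gives 9.4%; compound 3 `CCOC(=O)N1CCN(C(=O)c2nc(Nc3cc(C4CC4)[nH]n3)c3cc(Cl)ccc3n2)C[C@H]1C` gives 42.4%.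

Compound 3 stands highest of the three in this assay, and both steps to it lie beyond the scatter. Compound 2 and compound 3 differ in their cores by hydrogen in place of (isopropylcarbonyl)oxy on a saturated chain carbon bound to an oxygen next to a carbonyl group and a saturated chain carbon, and a number 33 percentage points higher from compound 2 to compound 3 (beyond the scatter). Compound 1 carries a larger group still, and a number 49.3 percentage points higher from compound 1 to compound 3 (beyond the scatter).

Compound 4 `CC(C)OC(=O)N1CCN(C(=O)c2nc(Nc3cc(C4CC4)[nH]n3)c3cc(Cl)ccc3n2)C[C@H]1C` has not been measured. It differs from compound 3 by methyl in place of hydrogen on a saturated chain carbon bound to an oxygen next to a carbonyl group and a saturated chain carbon. The same kind of change, methyl in place of hydrogen, is seen between compound 2 and compound 1 as methyl in place of hydrogen on a saturated chain carbon bound to a carbonyl carbon and two saturated chain carbons, where a number 16.3 percentage points lower from compound 2 to compound 1 (beyond the scatter). The place is not the same, however: in compound 1 the methyl enters on a saturated chain carbon bound to a carbonyl carbon and two saturated chain carbons, whereas in compound 4 it enters on a saturated chain carbon bound to an oxygen next to a carbonyl group and a saturated chain carbon. Resting on the single earlier step, a modest drop is expected, a number 9.4 percentage points lower from compound 3 to compound 4 (within the scatter), with wide uncertainty since the surroundings differ. Compound 4 is estimated at 33%, between 12% and 54%.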

Compound 4, a percentage reported as inhibition, at one concentration (the size of the read-out at that concentration, not a potency): 26.9%
Compound 4: the middle estimate sits 6.1 percentage points above what was measured; the measured number falls inside the stated range.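

In this assay the new step reads a number 15.5 percentage points lower from compound 3 to compound 4 (beyond the scatter), while the steps from the two larger groups to methyl on that carbon read a number 17.5 percentage points higher from compound 2 to compound 4 (beyond the scatter) and a number 33.8 percentage points higher from compound 1 to compound 4 (beyond the scatter). Methyl in place of hydrogen therefore lowered the number by much the same amount in both settings where it can be read: the same change on two cores in this assay, a number 16.3 percentage points lower (beyond the scatter) from compound 2 to compound 1 and a number 15.5 percentage points lower (beyond the scatter) from compound 3 to compound 4, 0.8 percentage points apart, within the scatter of two such steps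

This agreement rests on a single pair of steps, and the methyl enters at a different place in each, so it does not show that the change would keep its size elsewhere in the series, nor does it give a reason for the drop.

As far as these compounds go, what an amine, a carboxylic acid or a longer chain such as butyl would give in place of methyl on that saturated chain carbon remains open. All the compounds shown also keep the same remaining structure, so the size of the methyl step with a different group elsewhere on the molecule is open too.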